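Alpha-1 series: methyl on the pendant phenyl of compound 3

This account rests on a few compounds, and the source may have more. Where it says the series, first, only, none or still open, it means among the compounds named here.

Measured compounds:
Compound 1, `O=c1[nH]c2cc[nH]c2c(=O)n1CCN1CCN(c2ccccc2Cl)CC1`, gives 0.94 nM in an assay for binding affinity to Adrenergic receptor alpha-1 (Rattus norvegicus); on this read-out lower numbers stand for stronger inhibition and higher numbers for weaker inhibition.
Compound 2, `COc1ccccc1N1CCN(CCn2c(=O)[nH]c3cc(-c4ccccc4)[nH]c3c2=O)CC1`, gives 0.52 nM in this assay.
Compound 3, `O=c1[nH]c2cc(-c3ccccc3)[nH]c2c(=O)n1CCN1CCN(c2ccccc2Cl)CC1`, gives 1.08 nM in this assay.

Compound 3 shows the highest number of the three, but the gap to compound 1 is within the scatter; only the gap to compound 2 lies beyond it. The step of a 1.1-fold higher number from compound 1 to compound 3 (0.06 log units; within the scatter) shows that adding the phenyl to the shared core left the number essentially where it was. Among the compounds with values here, the step of a 2.1-fold higher number from compound 2 to compound 3 (0.32 log units; beyond the scatter) is the one modest change seen, and it concerns the other aryl ring, not the phenyl.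

Compound 4, `Cc1ccc(-c2cc3[nH]c(=O)n(CCN4CCN(c5ccccc5Cl)CC4)c(=O)c3[nH]2)cc1`, differs from compound 3 by methyl in place of hydrogen on an aromatic carbon. Within the data shown here, no measured step bears directly on a methyl entering here; the nearest evidence is the phenyl step from compound 1 to compound 3, which was within the scatter. The step of a 1.0-fold higher number from compound 3 to compound 4 (0.01 log units; within the scatter) is therefore expected to stay within the scatter. For compound 4 the estimate in this assay is 1.1 nM, with a range from 0.5 nM to 2.5 nM.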

Compound 4, inhibition constant: 17.3 nM
The estimate for compound 4 lay 16-fold (1.20 log units) below the measured number; measured number outside the range, above it.
By their numbers in this assay, from the lowest: compounds 2, 1 and 3 (each within the scatter of the next, the first and the last beyond it); then compound 4.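

Substitution on the pendant phenyl matters even though the phenyl itself did not: a single methyl, para to a large group, gives a 16-fold higher number from compound 3 to compound 4 (1.20 log units; beyond the scatter) in this series. Measured from the hydrogen of the shared core, 4-methylphenyl gives an 18-fold higher number from compound 1 to compound 4 (1.26 log units; beyond the scatter) while the plain phenyl gave only a 1.1-fold higher number from compound 1 to compound 3 (0.06 log units; within the scatter) within the scatter, so the shift in this pair appears only once the methyl is present. No measurement shown accounts for the size of this step.

On these data alone, whether the shift is particular to methyl or follows any group at this carbon remains open, and fluoro, methoxy or hydroxyl there would help separate these readings. Also open, as far as these compounds go, is whether methoxy in place of chloro on the other aryl ring would change the number for the 4-methylphenyl compound.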